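The source may report more compounds than this note shows. Statements on the series, on what has been measured and on what is new or still open speak of the compounds shown alone.

Among the compounds with values here, compound 2 `CC(=O)n1cc(/C=C(/C(=O)O)c2ccccc2)c2cc(OCc3ccccc3)ccc21` is the only compound of this set with a reading in a functional assay on LNCaP cells (Homo sapiens) for cytotoxicity, read by MTT assay, with a stated time of 72 h (on this read-out higher numbers stand for weaker inhibition and lower numbers for stronger inhibition), and that reading is a limit rather than a number, > 100000 nM, sitting at the limit of > 100000 nM in this assay, at which 1 of the 3 values shown sits. Compound 1 `O=C(O)/C(=C/c1c[nH]c2ccc(OCc3ccccc3)cc12)c1ccccc1` stands in this assay at "not determined" (no result reported). Compound 3 `COc1ccc(/C(=C\c2c[nH]c3ccc(OCc4ccccc4)cc23)C(=O)O)cc1` stands in this assay at "not determined" (no result reported). Within the data shown here, no step between measured compounds can be drawn from these three. Compound 4 `COc1cccc(/C(=C\c2cn(C(C)=O)c3ccc(OCc4ccccc4)cc23)C(=O)O)c1` differs from compound 2 in one place: methoxy in place of hydrogen on an aromatic carbon. With nothing measured to lean on, the expected step is a step that the limit leaves unreadable from compound 2 to compound 4, none beyond the scatter. Compound 4 is thus estimated to give about 150000 nM in this assay, within 50000 nM to 500000 nM, and most probably again only a limit.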

Compound 4, half-maximal inhibitory concentration: 65100 nM
Beside the measured number, compound 4's estimate is 2.3-fold (0.36 log units) above it; measured number inside the range.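

In this assay, the change from phenyl to 3-methoxyphenyl gives an at least 1.5-fold lower number from compound 2 to compound 4 (0.18 log units; that floor lies within the scatter). Compound 2 stands at a limit and not at a number: the limit of > 100000 nM in this assay, at which 1 of the 4 values shown sits. The carbon carrying the methoxy therefore accepts this group with a numerical reading for compound 4, but the true size of the step remains unknown, and nothing shown separates it from the scatter. Going by these compounds, whether a hydroxyl group or an amine on the same aromatic carbon would give a lower number stays open. So does whether a longer chain, such as ethoxy, would do so.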